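Removing a Fluorine from a Substance-P Receptor Binder

The source may hold more compounds than are shown below. What is called first, only, known or untested is meant among the compounds shown, and "the series" means these compounds.

Within the data shown here, compound 1 `C[C@@H](O[C@H]1CN(C(=O)OC(C)(C)C)[C@@H](CO)[C@@H]1c1ccc(F)cc1)c1cc(C(F)(F)F)cc(C(F)(F)F)c1` is the stronger of the two compounds measured so far. In an assay on CHO cells for displacement of a labelled ligand from Substance-P receptor (Homo sapiens) (on this read-out higher numbers stand for weaker inhibition and lower numbers for stronger inhibition), compound 1 gives 0.28 nM, the lowest number shown. Compound 2 `C[C@@H](O[C@@H]1[C@@H](c2ccc(F)cc2)CN2C(=O)OC[C@H]12)c1cc(C(F)(F)F)cc(C(F)(F)F)c1` gives 1 nM in this assay, a gap that lies beyond the usual scatter, so compound 1 stands clearly ahead. Compound 3 `C[C@@H](O[C@H]1CN(C(=O)OC(C)(C)C)[C@@H](CO)[C@@H]1c1ccccc1)c1cc(C(F)(F)F)cc(C(F)(F)F)c1` has not been measured. Compared with compound 1, the change is hydrogen in place of fluoro on an aromatic carbon, so the 4-fluorophenyl becomes a plain phenyl. Among the measured compounds shown here, no measured pair shows this exact change, so the expectation rests on compound 1 alone. The step is expected to be small: a 2.1-fold higher number from compound 1 to compound 3 (0.33 log units; beyond the scatter) is estimated as a slight weakening, near the edge of the scatter. Compound 3 is therefore estimated at 0.6 nM in this assay, with a range from 0.2 nM to 2 nM.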

Compound 3, half-maximal inhibitory concentration: 0.63 nM
The estimate for compound 3 lay 1.1-fold (0.02 log units) below the measured number; the range from low to high includes it.
By their numbers in this assay, from the lowest: compound 1; then compounds 3 and 2 (each within the scatter of the next).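

In this assay, among these compounds, the swap of fluoro for hydrogen gives a 2.3-fold higher number from compound 1 to compound 3 (0.35 log units; beyond the scatter) and so is the first single change whose size can be read. The fluoro on the aromatic ring therefore makes a measurable difference here, though a modest one, and compound 3 with its plain phenyl still reaches 0.63 nM in this read-out, so binding of this order does not depend on that fluorine. Nothing available explains why removing the fluorine moves the number in this direction.

The compounds shown leave open how a chloro, a methyl, a methoxy or an amine would compare with fluoro and hydrogen at this same place on the ring. They also leave open whether the same swap would produce a similar step in compound 2, which carries the same 4-fluorophenyl.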